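Replacing carboxy with hydroxymethyl in compound 2

The compounds below may be only part of what the source reports. "The series", "measured", "known", "first", "only" and "open" are said of these compounds alone.

Compound 1 `O=C(O)c1cc(-c2ccc(Oc3ccccc3)cc2)nn1C1CCCN(C(=O)CCl)C1`: 400 nM
Compound 2 `C=CC(=O)N1CCCC(n2nc(-c3ccc(Oc4ccccc4)cc3)cc2C(=O)O)C1`: > 60000 nM (a limit)
Compound 3 `C/C=C/C(=O)N1CCCC(n2nc(-c3ccc(Oc4ccccc4)cc3)cc2C(=O)O)C1`: > 60000 nM (a limit)

These values come from a functional assay on Maver1 cells (Homo sapiens) for inhibition, read by luminescence and CellTiter-Glo, with a stated time of 72 h; a higher number here means a weaker inhibitor, a lower number a stronger inhibitor. Compound 2 gives only a limit, > 60000 nM, and not a number. It sits at the limit of > 60000 nM in this assay, at which 2 of the 3 values shown sit.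

Compound 4 `C=CC(=O)N1CCCC(n2nc(-c3ccc(Oc4ccccc4)cc3)cc2CO)C1` differs from compound 2 in one group: hydroxymethyl in place of carboxy on an aromatic carbon. In short, it carries hydroxymethyl in place of carboxy on an aromatic carbon.

Among the measured compounds shown here, no measured step tests this swap. The measured steps all concern the group on the carbonyl carbon. Two are large: an at least 150-fold higher number from compound 1 to compound 2 (2.17 log units; beyond the scatter), and an at least 150-fold higher number from compound 1 to compound 3 (2.17 log units; beyond the scatter). The third is a step that the two limits leave unreadable from compound 2 to compound 3. For the measured compounds named here, the first of these, an at least 150-fold higher number from compound 1 to compound 2 (2.17 log units; beyond the scatter), shows only that one change on the shared core can move the number far. A modest move towards a lower number in this assay is therefore expected, though compound 4 may stay at the limit.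

The estimate is an at least 4.0-fold lower number from compound 2 to compound 4 (0.60 log units; beyond the scatter). For compound 4 the expected value is 15000 nM, within an estimated range of 2000 nM to 60000 nM.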

Compound 4, half-maximal inhibitory concentration: 30500 nM
Beside the measured number, compound 4's estimate is 2.0-fold (0.31 log units) below it; measured number inside the range.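

In this assay, hydroxymethyl in place of carboxy on this aromatic carbon gives an at least 1.9-fold lower number from compound 2 to compound 4 (0.29 log units; that floor lies within the scatter). Among the compounds with vinyl or prop-1-en-1-yl on the carbonyl carbon, compound 4 alone gives a readable number, 30500 nM, so with the vinyl group a carboxy at this position is not needed for a number to appear. Compound 2 gives only a limit, so the step is a floor and its full size remains unknown: the limit of > 60000 nM in this assay, at which 2 of the 4 values shown sit.

The compounds shown leave open how other groups at this position, such as an amine or a primary amide, would read. They also leave open whether hydroxymethyl would give a lower or higher number with chloromethyl on the carbonyl carbon in place of vinyl.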